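The source may hold more compounds than are shown below. What is called first, only, known or untested is meant among the compounds shown, and "the series" means these compounds.

Measured compounds:
compound 1, `O=c1c2cnn(-c3ccc(F)cc3)c2ncn1CC1(O)CCN(Cc2ccncc2)CC1`, in an assay on Sf21 cells for inhibition of ubiquitin carboxyl-terminal hydrolase 7 (Homo sapiens), read by spectrophotometry, with stated times of 30 min and 2 h; on this read-out lower numbers stand for stronger inhibition and higher numbers for weaker inhibition: "not determined" (no result reported)
compound 2, `O=c1c2cnn(-c3ccc(F)cc3)c2ncn1CC1(O)CCN(Cc2ccccc2Br)CC1`, in this assay: 3100 nM
compound 3, `Cc1ccccc1CN1CCC(O)(Cn2cnc3c(cnn3-c3ccc(F)cc3)c2=O)CC1`, in this assay: "not determined" (no result reported)

Compound 3 stands without a single number in this assay; compound 1 is the one further entry without a number. The only figure in the series is that of compound 2, which gives 3100 nM in this assay. Compound 4, `COC(=O)c1ccc(CN2CCC(O)(Cn3cnc4c(cnn4-c4ccc(F)cc4)c3=O)CC2)c(Cl)c1`, is still to be measured. It differs from compound 3 by 2-chloro-4-(methoxycarbonyl)phenyl in place of 2-methylphenyl on a saturated chain carbon bound to an amine nitrogen in a ring. Among the compounds with values here, no step between measured compounds exists to scale this change, so the expectation for compound 4 rests on the single value of compound 2 alone; no step beyond the usual scatter is expected in either direction, and the range is set wide. Compound 4 is expected to give about 3000 nM in this assay, between 700 nM and 13000 nM.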

Compound 4, half-maximal inhibitory concentration: 800 nM
Compound 4: middle estimate off by 3.8-fold (0.57 log units), on the high side; low and high end bracket the measured number.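

In this assay the series gains its first readable step, a 3.9-fold lower number from compound 2 to compound 4 (0.59 log units; beyond the scatter), and the two compounds differ only in their substituted phenyl group. This position is therefore sensitive to the choice of aryl group, and this change goes with stronger inhibition. No evidence on the reason for the step is available. Still open, on these data alone, is whether the chlorine or the methoxycarbonyl carries the step. Also open, as far as these compounds go, is whether a carboxylic acid or a primary amide in place of the methyl ester would preserve it.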